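A few compounds are considered here, and "the series" means these few. Any claim that something is new, unique, unknown or untested is made for them only; others in the source may bear on it.

Of the compounds shown here, two have been measured so far in a functional assay on L1210 cells (Mus musculus) for inhibition (a higher number here means a weaker inhibitor, a lower number a stronger inhibitor), and they lie far apart. Compound 1 (`C=C1C(n2ccc(N)nc2=O)O[C@H](CO)[C@@H]1O`) gives 2000 nM, while compound 2 (`C=C1[C@@H](O)[C@H](n2cnc3c(Cl)nc(N)nc32)O[C@@H]1CO`) gives 441000 nM as the higher of the two numbers. That makes compound 2 the weaker inhibitor of the pair, by a gap beyond the usual scatter of repeated measurements. Compound 3 (`C=C1[C@@H](O)[C@H](n2cnc3c(N(C)C)nc(N)nc32)O[C@@H]1CO`) is compound 2 with a single change, dimethylamino in place of chloro on an aromatic carbon. Within the data shown here, no measured pair shows this exchange, so the data give no direct guide to its size. The expectation in this assay is therefore no step beyond the scatter, with neither direction favoured. The estimate puts a 1.1-fold lower number from compound 2 to compound 3 (0.04 log units; within the scatter) inside that scatter. Compound 3 is expected to give 400000 nM with a likely range of 100000 nM to 1000000 nM around that estimate.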

Compound 3, half-maximal inhibitory concentration: > 500000 nM
Compound 3 was reported as a limit (the forecaster's own chance of this, stated with the estimate: 35%); middle value at least 1.2-fold (0.09 log units) from the limit.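

In this assay compound 3 gives > 500000 nM, which is a limit of the assay and not a number. Replacing chloro with dimethylamino on this aromatic carbon, next to the ring nitrogen, gives an at least 1.1-fold higher number from compound 2 to compound 3 (0.05 log units; that floor lies within the scatter), so this exchange shows no sign of a stronger inhibitor, even though the entering group has 3 heavy atoms and 1 hydrogen-bond acceptor. The true size of the step stays unknown because the reading stops at a limit: the limit of > 500000 nM in this assay, at which 1 of the 3 values shown sits.

Going by these compounds, it remains open whether a primary amine or a methoxy group on this same carbon would give a lower number than chloro does. On these data alone, it is also open how diethylamino, with longer chains on the nitrogen, would compare with dimethylamino.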